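A few compounds are considered here, and "the series" means these few. Any claim that something is new, unique, unknown or untested is made for them only; others in the source may bear on it.

In a functional assay for agonist activity at G protein-coupled receptor 88 (Homo sapiens), read by HTRF and cAMP accumulation (a higher number here means that more compound is needed for the effect, a lower number that less compound is needed), compound 3 `CC(C)C[C@H](N)CN(C(=O)[C@@H]1C[C@H]1c1ccccc1)c1ccc(-c2cccs2)cc1` gives 1500 nM. The two related compounds are within the usual scatter of it: compound 1 `CC(C)C[C@H](N)CN(C(=O)[C@@H]1C[C@H]1c1ccccc1)c1ccc(-c2ccccc2)cc1` gives 880 nM, with a 1.7-fold higher number from compound 1 to compound 3 (0.23 log units; within the scatter), and compound 2 `CC(C)C[C@H](N)CN(C(=O)[C@@H]1C[C@H]1c1ccccc1)c1ccc(-c2ccsc2)cc1` gives 1200 nM, with a 1.3-fold higher number from compound 2 to compound 3 (0.10 log units; within the scatter). Compound 4 `CC(C)C[C@H](N)CN(C(=O)[C@@H]1C[C@H]1c1ccccc1)c1ccc(-c2ccoc2)cc1` differs from compound 3 only in that (furan-3-yl in place of thiophen-2-yl on an aromatic carbon). For the measured compounds named here, the steps that bear on this all exchange the small aromatic group at the same place: a 1.4-fold higher number from compound 1 to compound 2 (0.13 log units; within the scatter), a 1.7-fold higher number from compound 1 to compound 3 (0.23 log units; within the scatter) and a 1.3-fold higher number from compound 2 to compound 3 (0.10 log units; within the scatter), each within the scatter. A change of this kind is therefore expected to give no step beyond the scatter, a 1.2-fold lower number from compound 3 to compound 4 (0.06 log units; within the scatter). Compound 4 is estimated at 1300 nM in this assay, with a range from 500 nM to 3500 nM.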

Compound 4, half-maximal effective concentration: 2000 nM
For compound 4 the middle estimate is 1.5-fold (0.19 log units) below the measured one, and the stated range covers the measured number.
By their numbers in this assay, from the lowest: compounds 1, 2, 3 and 4 (each within the scatter of the next, the first and the last beyond it).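

In this assay the furan-3-yl ring of compound 4 stays close to both thiophene rings, with a 1.3-fold higher number from compound 3 to compound 4 (0.12 log units; within the scatter) and a 1.7-fold higher number from compound 2 to compound 4 (0.22 log units; within the scatter) as its steps, so a ring oxygen and a ring sulfur are not told apart at this place. Against phenyl the picture differs: a 2.3-fold higher number from compound 1 to compound 4 (0.36 log units; beyond the scatter) is the first step at this place to pass the scatter, though only modestly. Nothing measured here accounts for that step.

The compounds shown leave open whether a ring holding nitrogen, such as pyridin-3-yl, would give a larger step. The same is open for a methyl or chlorine added to the phenyl ring, or for an amine or carboxylic acid at this place.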